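A few compounds are considered here, and "the series" means these few. Any claim that something is new, unique, unknown or untested is made for them only; others in the source may bear on it.

Compound 3 `C[C@@H](NC1CCN(CCCc2c[nH]c3ccc(-n4ccnc4)cc23)CC1)c1ccccc1` gives 110 nM in an assay on CHO cells for displacement of a labelled ligand from 5-hydroxytryptamine receptor 1B (Homo sapiens); on this read-out lower numbers stand for stronger inhibition and higher numbers for weaker inhibition; this is the highest of the three numbers, but compound 2 `OC[C@H](NC1CCN(CCCc2c[nH]c3ccc(-n4ccnc4)cc23)CC1)c1ccccc1` with 100 nM and compound 1 `O=S(=O)(NCC1CCN(CCCc2c[nH]c3ccc(-n4cnnc4)cc23)CC1)c1ccccc1` with 60 nM both lie within the scatter of it. Compound 4 `CNS(=O)(=O)Cc1ccc2[nH]cc(CCCN3CCC(N[C@H](C)c4ccccc4)CC3)c2c1` differs from compound 3 in one place: (methylsulfamoyl)methyl in place of 1H-imidazol-1-yl on an aromatic carbon. Among the measured pairs, only a 1.1-fold higher number from compound 2 to compound 3 (0.04 log units; within the scatter) is a single change, and it sits on the amine nitrogen rather than on the aromatic carbon, so it does not bear on this new change. Compound 1 differs from compound 3 in two places at once, so its value cannot be read as a single step. For the measured compounds named here, with no matching step to lean on, no shift beyond the scatter is expected. Compound 4 is therefore estimated at 100 nM, between 30 nM and 350 nM, which would mean a 1.1-fold lower number from compound 3 to compound 4 (0.04 log units; within the scatter).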

Compound 4, half-maximal inhibitory concentration: 260 nM
For compound 4 the middle estimate is 2.6-fold (0.41 log units) below the measured one; the range from low to high includes it.
By their numbers in this assay, from the lowest: compounds 1, 2 and 3 (each within the scatter of the next); then compound 4.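

This is the first single change shown at this aromatic carbon, and it shows that the group there matters: in this assay, replacing the 1H-imidazol-1-yl ring with the ring-free (methylsulfamoyl)methyl chain gives a 2.4-fold higher number from compound 3 to compound 4 (0.37 log units; beyond the scatter). The step is modest, and compound 4 still gives 260 nM in this assay. Nothing available here explains the shift.

From the compounds shown here alone, whether a simple nitrile or a carboxylic acid at this carbon would give a lower or a higher number remains open. So does whether the same step would appear with 2-hydroxy-1-phenylethyl on the amine nitrogen.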